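The source may hold more compounds than are shown below. What is called first, only, known or untested is meant among the compounds shown, and "the series" means these compounds.

Compound 1, with the structure `O=C(CN1CCN(c2ccc(Cl)cc2)CC1)N1CCN(c2nnc(-c3ccccc3)c(-c3ccccc3)n2)CC1`, serves as the starting point of this account. In an ADME assay on NIH3T3 cells (Mus musculus) for cytotoxicity, read by MTT assay, with a stated time of 24 h (on this read-out higher numbers stand for weaker inhibition and lower numbers for stronger inhibition), compound 1 gives 113000 nM. Compound 2, with the structure `O=C(CN1CCN(c2ccc([N+](=O)[O-])cc2)CC1)N1CCN(c2nnc(-c3ccccc3)c(-c3ccccc3)n2)CC1`, carries the change described as nitro in place of chloro on an aromatic carbon on the same core. For compound 2 this assay reports only a limit, > 886000 nM. The step of an at least 7.8-fold higher number from compound 1 to compound 2 (0.89 log units; beyond the scatter) is therefore known only as a lower bound, because the value of compound 2 sits at the limit of > 886000 nM in this assay, at which 1 of the 3 values shown sits.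

Compound 3, with the structure `Cc1ccc(-c2nnc(N3CCN(C(=O)CN4CCN(c5ccc(Cl)cc5)CC4)CC3)nc2-c2ccc(C)cc2)cc1`, has a different core; the difference between the two cores is not broken down here. In this assay compound 3 gives 567000 nM, the highest number among the measured compounds, with compound 1 giving a clearly lower one.

Compound 4, with the structure `Cc1ccc(-c2nnc(N3CCN(C(=O)CN4CCN(c5ccc([N+](=O)[O-])cc5)CC4)CC3)nc2-c2ccc(C)cc2)cc1`, has not yet been measured. It differs from compound 3 by nitro in place of chloro on an aromatic carbon, the same change that carries compound 1 to compound 2, made at a place described in the same words. Since that change produced a step of at least modest size in this assay, compound 4 is expected to move by a comparable amount, estimated as a 4.4-fold higher number from compound 3 to compound 4 (0.64 log units; beyond the scatter), resting on an at least 7.8-fold higher number from compound 1 to compound 2 (0.89 log units; beyond the scatter). Given that compound 3 already starts from a high number, compound 4 is estimated at 2500000 nM, within a range from 700000 nM to 9000000 nM, and it is expected that this assay will most likely report only a limit for it.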

Compound 4, half-maximal inhibitory concentration: > 844000 nM
Compound 4 ended at the assay's limit; the forecaster's own chance of this, stated with the estimate: 75%; the middle value lies beyond the limit too.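

In this assay compound 4 gives > 844000 nM, which is a limit of the assay and not a number. Nitro in place of chloro on the core of compound 3 therefore yields an at least 1.4-fold higher number from compound 3 to compound 4 (0.17 log units; that floor lies within the scatter), and this floor alone does not establish a real change on that core, although the true step may be considerably larger. Set beside the earlier step, the result shows that both nitro compounds ended at a limit of the assay, but it does not show whether the size of the step carries over from one core to the other, and so neither a shared effect nor a core-dependent one can be claimed: the same change on two cores in this assay, an at least 7.8-fold higher number (0.89 log units; beyond the scatter) from compound 1 to compound 2 and an at least 1.4-fold higher number (0.17 log units; that floor lies within the scatter) from compound 3 to compound 4; the limit leaves it open whether they differ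

The compounds shown carry only chloro or nitro at this place on the aromatic ring, on two cores and in a single assay, so it remains open how an amine or a carboxylic acid in the same place would read in this assay. Also open, on these data alone, is whether the change would follow the same course on a core bearing a longer chain in place of the methyl groups of compound 3.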